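A Dimethylphenyl Ether on the Shared Core

The compounds below may be only part of what the source reports. "The series", "measured", "known", "first", "only" and "open" are said of these compounds alone.

Three chlorophenyl ethers share one core. In a functional assay on HL-60 cells (Homo sapiens) for antiproliferative activity, read by MTT assay, with a stated time of 72 h (on this read-out higher numbers stand for weaker inhibition and lower numbers for stronger inhibition), compound 1 (`NC1=NC2(CCOCC2)N(OCCCOc2ccc(Cl)cc2)C(N)=N1`) gives 330 nM, compound 2 (`NC1=NC2(CCOCC2)N(OCCCOc2cccc(Cl)c2Cl)C(N)=N1`) gives 440 nM and compound 3 (`NC1=NC2(CCOCC2)N(OCCCOc2ccccc2Cl)C(N)=N1`) gives 660 nM. Compound 3 therefore stands within the scatter of both other compounds. Compound 4 (`Cc1cc(C)cc(OCCCON2C(N)=NC(N)=NC23CCOCC3)c1`) has 3,5-dimethylphenyl in place of 2-chlorophenyl on an oxygen on a saturated carbon.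

The measured steps that bear on this change all alter the same group. They are a 2.0-fold higher number from compound 1 to compound 3 (0.30 log units; within the scatter), a 1.5-fold higher number from compound 2 to compound 3 (0.18 log units; within the scatter) and a 1.3-fold higher number from compound 1 to compound 2 (0.12 log units; within the scatter). Among the measured compounds shown here, none of them leaves the scatter, although no measured compound carries a methyl group, so the evidence for this replacement is indirect. No step beyond the scatter is therefore expected in this assay. The expected change is a 1.5-fold lower number from compound 3 to compound 4 (0.17 log units; within the scatter). For compound 4, the estimated value is 450 nM, with an expected range from 170 nM to 1200 nM.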

Compound 4, half-maximal inhibitory concentration: 720 nM
Beside the measured number, compound 4's estimate is 1.6-fold (0.20 log units) below it, and the stated range covers the measured number.
By their numbers in this assay, from the lowest: compounds 1, 2, 3 and 4 (each within the scatter of the next, the first and the last beyond it).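

In this assay the change to 3,5-dimethylphenyl gives a 1.1-fold higher number from compound 3 to compound 4 (0.04 log units; within the scatter) and, from the dichlorinated ether, a 1.6-fold higher number from compound 2 to compound 4 (0.21 log units; within the scatter) at the same place, so a phenyl ether carrying no chlorine stays within the scatter of these two chlorophenyl ethers. Only the comparison with the 4-chlorophenyl ether, a 2.2-fold higher number from compound 1 to compound 4 (0.34 log units; beyond the scatter) and a modest step, leaves the scatter, and it is the only step among these compounds to do so. Nothing measured here accounts for these steps.

The compounds shown leave open how an amine or a carboxylic acid on the aromatic ring would read in this assay on the shared core. They also leave open whether a single methyl group would read like the two in compound 4, and what a longer chain would do.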